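The source may report more compounds than this note shows. Statements on the series, on what has been measured and on what is new or still open speak of the compounds shown alone.

- compound 1 `COc1cc(C2OC(c3ccc(N(C)C)cc3)=NN2C=O)cc(OC)c1OC`: 0.12 uM
- compound 2 `COc1cc(C2OC(c3ccc(N(C)C)cc3)=NN2C(=O)CO)cc(OC)c1OC`: 0.043 uM

In a functional assay on NCI-H460 cells (Homo sapiens) (on this read-out lower numbers stand for an effect already at smaller amounts and higher numbers for an effect only at larger amounts of compound), compound 2 holds the lower of the two numbers, at 0.043 uM. Compound 3 `COc1cc(C2OC(c3ccc(N(C)C)cc3)=NN2C(=O)CNC=O)cc(OC)c1OC` carries formylamino in place of hydroxy on a saturated chain carbon bound to a carbonyl carbon, formylamino in place of hydroxy on a saturated chain carbon bound to a carbonyl carbon. For the measured compounds named here, only one measured step bears on this change: a 2.8-fold lower number from compound 1 to compound 2 (0.45 log units; beyond the scatter), a modest move at that same side chain. It does not test the new group, so the direction is uncertain, with a slight lean towards a higher number. Expected is a 1.6-fold higher number from compound 2 to compound 3 (0.21 log units; within the scatter), no larger than that modest step. For compound 3 the estimated value is 0.07 uM, with an expected range from 0.02 uM to 0.25 uM as the likely span.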

Compound 3, concentration for half-maximal effect: 0.04 uM
The estimate for compound 3 lay 1.8-fold (0.24 log units) above the measured number; measured number inside the range.
By their numbers in this assay, from the lowest: compounds 3 and 2 (each within the scatter of the next); then compound 1.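

In this assay, formylamino in place of hydroxy on the saturated chain carbon bound to a carbonyl carbon gives a 1.1-fold lower number from compound 2 to compound 3 (0.03 log units; within the scatter), so the two groups are not told apart at this position. (Formylamino)methyl in place of hydrogen on the carbonyl carbon gives a 3.0-fold lower number from compound 1 to compound 3 (0.48 log units; beyond the scatter), so hydroxymethyl is not the only replacement that reads beyond the scatter from compound 1. Nothing available explains why the two side chains read alike. Open, from the compounds shown here alone, is whether a free amine, a carboxylic acid or a longer chain at this place would hold the number at this level.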